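The compounds below may be only part of what the source reports. "The series", "measured", "known", "first", "only" and "open" are said of these compounds alone.

Compound 2 `COc1cc(C(=O)N2CC[C@H](O)[C@@H](C)C2)cc2nc(NCc3cccc(Cl)c3)oc12`, measured in an assay on isolated protein for inhibition of thyroid hormone receptor beta (Homo sapiens), read by fluorescence, with a stated time of 30 min (a lower number here means a stronger inhibitor, a higher number a weaker inhibitor), gives 120 nM and so holds the highest of the two numbers. Its nearest neighbour, compound 1 `COc1cc(C(=O)N2CCC(O)C(C)C2)cc2nc(NCc3cccc(Cl)c3)oc12`, gives 25 nM in this assay, and the step of a 4.8-fold higher number from compound 1 to compound 2 (0.68 log units; beyond the scatter) is the only measured one; the two compounds share all atoms and bonds, so it rests on the fact that one of compounds 1 and 2 is drawn with a defined configuration and the other without, at the place where they differ alone. Compound 3 `COc1cc(C(=O)N2CC(C)C(O)CC2C2CC2)cc2nc(NCc3cccc(Cl)c3)oc12` differs from compound 2 by 2-cyclopropyl-4-hydroxy-5-methylpiperidin-1-yl in place of 4-hydroxy-3-methylpiperidin-1-yl on a carbonyl carbon, a change of a different kind: a substituent is added to the piperidine rather than a configuration drawn or left open. Within the data shown here, no measured step speaks to that addition, and the stereo step gives only a sense of how much a change at this ring can move the number. Compound 3 is therefore expected to stay close to compound 2, with a step of a 1.3-fold lower number from compound 2 to compound 3 (0.12 log units; within the scatter), and its estimated value is 90 nM, within 25 nM to 350 nM.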

Compound 3, half-maximal inhibitory concentration: 8 nM
Compound 3: middle estimate off by 11-fold (1.05 log units), on the high side, outside the stated range (below it).
By their numbers in this assay, from the lowest: compound 3; then compound 1; then compound 2.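

In this assay, a cyclopropyl on a saturated ring carbon does not cost binding but goes with a stronger inhibitor, as a 3.1-fold lower number from compound 1 to compound 3 (0.49 log units; beyond the scatter) shows, and this is the cleaner reading of the addition since neither compound has a configuration drawn at the methyl- and hydroxyl-bearing ring carbons. The larger step, a 15-fold lower number from compound 2 to compound 3 (1.18 log units; beyond the scatter), joins that addition to a change in what is drawn, so only part of it can be given to the cyclopropyl, because compound 2 has a defined configuration where compound 3 leaves it open, the same difference that stands behind the earlier step: the fact that one of compounds 1 and 2 is drawn with a defined configuration and the other without, at the place where they differ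

Which stereoisomer of compound 3 carries the measured number stays open, since none of its stereocentres is drawn. Going by these compounds, whether a methyl or an isopropyl on that ring carbon would serve as the cyclopropyl does also stays open.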